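A few compounds are considered here, and "the series" means these few. Any claim that something is new, unique, unknown or untested is made for them only; others in the source may bear on it.

Compound 2 `CCN1CC/C(=C\c2cc(C(C)(C)C)c(O)c(C(C)(C)C)c2)C1=O` gives 44% in a functional assay on the whole organism for inhibition, with Rattus norvegicus as the target, at a dose of 3 mg/kg (on this read-out lower numbers stand for a weaker effect and higher numbers for a stronger effect at the one dose given), and stands lowest of the two numbers at hand; compound 1 `CN1CC/C(=C\c2cc(C(C)(C)C)c(O)c(C(C)(C)C)c2)C1=O` gives 58% in this assay. Compound 3 `CC(=O)N1CC/C(=C\c2cc(C(C)(C)C)c(O)c(C(C)(C)C)c2)C1=O` carries the change (acetyl in place of ethyl on an amide-type nitrogen in a ring). Going by the values given here, the single measured step, a number 14 percentage points lower from compound 1 to compound 2 (beyond the scatter), concerns the same amide-type nitrogen in a ring but a different change, so it bears only loosely on the present one. Among the compounds with values here, with that step as the only guide, a modest downward step or none beyond the scatter is expected for compound 3, a number 9 percentage points lower from compound 2 to compound 3 (within the scatter). Compound 3 is expected to give 35%, within 15% to 55%.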

Compound 3, a percentage reported as inhibition, in the whole organism at one dose (the size of the read-out at that dose, not a potency): 74%
For compound 3 the middle estimate is 39 percentage points below the measured one; measured number above the stated range.
By their numbers in this assay, from the lowest: compound 2; then compound 1; then compound 3.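

On the amide-type nitrogen in a ring, acetyl in place of ethyl gives (a number 30 percentage points higher from compound 2 to compound 3 (beyond the scatter)) in this assay, and acetyl in place of methyl gives (a number 16 percentage points higher from compound 1 to compound 3 (beyond the scatter)). The earlier pair showed only a fall at this position, whereas the acetyl group takes the number past both compound 1 and compound 2. No measurement at hand accounts for this rise.

Going by these compounds, whether the rise requires the acetyl group itself or extends to other acyl groups remains open. A propanoyl or methanesulfonyl group on the same nitrogen would separate these readings.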